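The source may hold more compounds than are shown below. What is called first, only, known or untested is meant among the compounds shown, and "the series" means these compounds.

Measured in an ADME assay on J774.A1 cells (Mus musculus) for cytotoxicity, read by MTT assay, with a stated time of 48 h; a higher number here means that more compound is tolerated, a lower number that less compound is tolerated:
- compound 1 `COc1cccc(CNC(=O)c2c([N+](=O)[O-])noc2-c2ccc(Cl)cc2)c1`: 68600 nM
- compound 2 `COc1ccc(CNC(=O)c2c([N+](=O)[O-])noc2-c2ccc(Cl)cc2Cl)cc1`: 80500 nM
- compound 3 `O=C(NCc1cccc(Br)c1)c1c([N+](=O)[O-])noc1-c1ccc(Cl)cc1Cl`: 71200 nM

Compound 3, at 71200 nM, lies within the scatter of both other compounds, so the three values cannot be told apart in this assay. The next compound, compound 4 `COc1cccc(CNC(=O)c2c([N+](=O)[O-])noc2-c2ccc(Cl)cc2Cl)c1`, carries methoxy in place of bromo on an aromatic carbon, so that 3-bromobenzyl becomes 3-methoxybenzyl.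

Among the measured compounds shown here, no measured step makes this exact exchange. The closest evidence is a 1.1-fold lower number from compound 2 to compound 3 (0.05 log units; within the scatter). That step also exchanges a methoxy for a bromo, though not at the same place, and it stays within the scatter. The 3-methoxybenzyl group also occurs in compound 1, which gives 68600 nM, a value within the scatter of the others. Three compounds are a thin basis, but nothing in them points to a step of any size, and no direction is favoured. The expected step is a 1.0-fold higher number from compound 3 to compound 4 (0.00 log units; within the scatter), which means that no change beyond the scatter is expected. In this assay the estimated value for compound 4 is 72000 nM, with an expected range from 45000 nM to 110000 nM.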

Compound 4, half-maximal cytotoxic concentration: 61200 nM
Beside the measured number, compound 4's estimate is 1.2-fold (0.07 log units) above it; low and high end bracket the measured number.
By their numbers in this assay, from the lowest: compounds 4, 1, 3 and 2 (each within the scatter of the next).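

In this assay, the exchange of bromo for methoxy on an aromatic carbon, meta to a large group, can now be read directly (a 1.2-fold lower number from compound 3 to compound 4 (0.07 log units; within the scatter)), and turning 3-bromobenzyl into 3-methoxybenzyl stays within the scatter at this place. Two further single-place comparisons become readable and also stay within the scatter: 3-methoxyphenyl in place of 4-methoxyphenyl (a 1.3-fold lower number from compound 2 to compound 4 (0.12 log units; within the scatter)) and chloro in place of hydrogen on an aromatic carbon of the core (a 1.1-fold lower number from compound 1 to compound 4 (0.05 log units; within the scatter)). Nothing at hand bears on why these steps are this small.

The compounds shown leave open whether this insensitivity holds for groups unlike bromo and methoxy, such as an amine or a carboxylic acid on the same aromatic carbon. They also leave open whether a longer chain between the amide nitrogen and the six-membered aromatic ring, or a nitrile in place of the nitro group on the shared core, would give a step beyond the scatter.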